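Hydroxy for methylamino on the shared fused core

A few compounds are considered here, and "the series" means these few. Any claim that something is new, unique, unknown or untested is made for them only; others in the source may bear on it.

Compound 1 `CNc1nncc2cncn12` stands at a limit on the numbers shown. In a functional assay for inhibition, with Homo sapiens as the target (on this read-out lower numbers stand for stronger inhibition and higher numbers for weaker inhibition), compound 1 gives > 48000 nM, a limit of the assay rather than a number. Its two measured neighbours are compound 2 `c1coc(CNc2nncc3cncn23)c1` and compound 3 `c1ncn2c(NC3CCCC3)nncc12`. In this assay compound 2 gives > 48000 nM, which is also a limit. In this assay compound 3 gives > 48000 nM, again a limit. The step that the two limits leave unreadable from compound 1 to compound 2 and the step that the two limits leave unreadable from compound 1 to compound 3 therefore have no readable size, because of the limit of > 48000 nM in this assay, at which 3 of the 3 values shown sit.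

Compound 4 `Oc1nncc2cncn12` differs from compound 1 by hydroxy in place of methylamino on an aromatic carbon. Neither measured step bears on this change directly: both steps alter what hangs from the nitrogen on the aromatic ring, while in compound 4 the methylamino leaves altogether and a hydroxy enters. With every neighbour sitting at the limit, no direction can be read, and the series gives no reason to expect a step beyond the scatter toward stronger inhibition. The estimated step is a step that the limit leaves unreadable from compound 1 to compound 4. The estimate for compound 4 in this assay is 100000 nM, with a range from 30000 nM to 300000 nM, and the most likely outcome is that only a limit is reported again.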

Compound 4, half-maximal inhibitory concentration: > 48000 nM
Compound 4: only a limit was reported; the forecaster's own chance of this, stated with the estimate: 85%; the middle value does not contradict the limit.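

No step can be read from compound 1 to compound 4, any more than from compound 1 to compound 2 or to compound 3, because all four compounds stand at the same limit of the assay and none gives a number: the limit of > 48000 nM in this assay, at which 4 of the 4 values shown sit.

The compounds shown leave open whether any change on the shared core gives a measurable inhibition in this assay, and how large such a step would be.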